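Methyl to Ethyl on the Amine in Two Cores

This account rests on a few compounds, and the source may have more. Where it says the series, first, only, none or still open, it means among the compounds named here.

Measured compounds:
compound 1, `CNCC(=O)Nc1cc(OC)ccc1C(=O)c1ccc(OC)c2c1OC(C)(C)C=C2`: 870 nM
compound 2, `CCNCC(=O)Nc1cc(OC)ccc1C(=O)c1ccc(OC)c2c1OC(C)(C)C=C2`: 2690 nM
compound 3, `CNCC(=O)Nc1cc(OC)ccc1C(=O)c1cc(OC)c(OC)c(OC)c1`: 690 nM

In a functional assay on HeLa cells (Homo sapiens) for antiproliferative activity, read by MTT assay, with a stated time of 48 h (on this read-out higher numbers stand for weaker inhibition and lower numbers for stronger inhibition), compound 1 gives 870 nM, compound 2 gives 2690 nM and compound 3 gives 690 nM. The difference between the core of compound 1 and the core of compound 3 is not broken down here; their values lie within the scatter of each other. Compound 2 arises from compound 1 by methyl in place of hydrogen on a saturated chain carbon bound to an amine nitrogen, a change that produced a 3.1-fold higher number from compound 1 to compound 2 (0.49 log units; beyond the scatter). Compound 4, `CCNCC(=O)Nc1cc(OC)ccc1C(=O)c1cc(OC)c(OC)c(OC)c1`, arises from compound 3 by methyl in place of hydrogen on a saturated chain carbon bound to an amine nitrogen, the same change made in this assay on the other core. Resting on a 3.1-fold higher number from compound 1 to compound 2 (0.49 log units; beyond the scatter), a step of similar size is expected, namely a 3.0-fold higher number from compound 3 to compound 4 (0.48 log units; beyond the scatter). Compound 4 is therefore estimated to give 2100 nM in this assay, with an expected range from 1000 nM to 4500 nM.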

Compound 4, half-maximal inhibitory concentration: 2100 nM
Compound 4: middle estimate and measured number agree at the digits printed; measured number inside the range.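

Methyl to ethyl on the amine gives a 3.0-fold higher number from compound 3 to compound 4 (0.48 log units; beyond the scatter) in this assay. Set beside the earlier step, the change carries from one core to the other at much the same size: the same change on two cores in this assay, a 3.1-fold higher number (0.49 log units; beyond the scatter) from compound 1 to compound 2 and a 3.0-fold higher number (0.48 log units; beyond the scatter) from compound 3 to compound 4, 1.0-fold (0.01 log units) apart, within the scatter of two such steps. This shows that the step held on these two cores, for this one change and in this one assay; it does not show that it would hold on any other core, and it gives no reason for the size of the step.

The compounds shown leave open how a primary amine, a propyl chain or an isopropyl group on the same amine nitrogen would read on either core. They also leave open whether the rise in the number would continue with a longer chain.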